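Removing an Octyl Segment from Compound 1

The source may hold more compounds than are shown below. What is called first, only, known or untested is meant among the compounds shown, and "the series" means these compounds.

Measured compounds:
Compound 1, `CCCCCCCCCCCCc1ccc(C(=O)/C=C/C(=O)O)cc1`: 5820 nM
Compound 2, `Cc1ccc(C)c(C(=O)/C=C/C(=O)O)c1`: 7860 nM
Compound 3, `CCc1c(C(=O)/C=C/C(=O)O)cc(C(C)C)cc1C(C)C`: 7610 nM

In a functional assay on HeLa cells (Homo sapiens) for inhibition, read by MTT assay, with a stated time of 72 h (on this read-out lower numbers stand for stronger inhibition and higher numbers for weaker inhibition), compound 1 gives the smallest of the three numbers, yet compound 3 and compound 2 both lie within the usual scatter of it, so the three cannot be told apart on this read-out. The step under study leads to compound 4, `CCCCc1ccc(C(=O)/C=C/C(=O)O)cc1`, not yet measured. Its change from compound 1 is hydrogen in place of octyl on a saturated chain carbon, four bonds along the chain from an aromatic carbon. Among the measured compounds shown here, since no two measured compounds differ in one place, no measured step can guide the expectation, and the three values are all close together. Compound 4 is therefore expected to land near compound 1, at most mildly weaker, with an estimate of 8500 nM in a range from 4000 nM to 18000 nM. The expected step is a 1.5-fold higher number from compound 1 to compound 4 (0.16 log units; within the scatter), essentially none beyond the scatter.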

Compound 4, half-maximal inhibitory concentration: 4780 nM
For compound 4 the middle estimate is 1.8-fold (0.25 log units) above the measured one; measured number inside the range.
By their numbers in this assay, from the lowest: compounds 4, 1, 3 and 2 (each within the scatter of the next).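

In this assay, hydrogen in place of octyl on this saturated chain carbon gives a 1.2-fold lower number from compound 1 to compound 4 (0.09 log units; within the scatter). Among the compounds shown here, this is the first single-place step that can be read here, and it shows that the octyl segment can be removed from compound 1 without a shift beyond the scatter. No measurement at hand offers an explanation for this result. From the compounds shown here alone, it remains open whether an amine or a hydroxyl group in place of octyl on this same carbon would also stay within the scatter. For the compounds shown here, a longer chain than the one in compound 1 is equally open.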